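Swapping a butyl chain for a methylthiophene on the sulfonamide aryl

The source may report more compounds than this note shows. Statements on the series, on what has been measured and on what is new or still open speak of the compounds shown alone.

Compound 1 `CCCCc1ccc(S(=O)(=O)Nc2ccc3c(c2)CCN(C)CC3)cc1` is the anchor of this small set. In an assay on isolated protein for displacement of a labelled ligand from 5-hydroxytryptamine receptor 6 (Homo sapiens), read by radioligand binding (a lower number here means a stronger inhibitor, a higher number a weaker inhibitor), compound 1 gives 1.26 nM, the lowest number among the three measured compounds, and its separation from each of the others is beyond the usual scatter, so it stands as the strongest binder of the group. Compound 2 `CCCCc1ccc(S(=O)(=O)Nc2ccc3c(c2)CN(C)C3)cc1`, which carries a smaller ring in its core, gives 5.01 nM in this assay. Compound 3 `Cc1cc2c(cc1NS(=O)(=O)c1ccc(-c3ccc(Cl)cc3)cc1)CCN(C)CC2`, with a chlorinated biphenyl on the sulfonamide and a methyl on the core, gives 15.9 nM in this assay.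

The next compound to be measured is compound 4 `Cc1ccc(-c2ccc(S(=O)(=O)Nc3ccc4c(c3)CCN(C)CC4)cc2)s1`. It differs from compound 1 in a single respect: 5-methylthiophen-2-yl in place of butyl on an aromatic carbon. Among the measured compounds shown here, no pair of measured compounds differs by exactly this change, so no measured step is available as a direct guide. Compound 3 shows that an aromatic biaryl-type sulfonamide on this core can still bind strongly, with 15.9 nM, while compound 1 shows the butyl version at 1.26 nM.

On that basis compound 4 is expected to give a number close to compound 1, with a modest shift toward a higher value that may or may not exceed the scatter; the expected step is a 2.4-fold higher number from compound 1 to compound 4 (0.38 log units; beyond the scatter). The estimate for compound 4 in this assay is 3 nM, with a range from 0.8 nM to 12 nM.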

Compound 4, inhibition constant: 6.31 nM
Compound 4: the middle estimate sits 2.1-fold (0.32 log units) below what was measured; measured number inside the range.
By their numbers in this assay, from the lowest: compound 1; then compounds 2 and 4 (each within the scatter of the next); then compound 3.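

Among the compounds shown here, at this position, on an aromatic carbon para to a large group, the change from butyl to 5-methylthiophen-2-yl in this assay gives a 5.0-fold higher number from compound 1 to compound 4 (0.70 log units; beyond the scatter) and so is the first measured change at this site, with a step that lies beyond the usual scatter but remains modest. The position therefore accepts a ring in place of an open chain with strong binding kept, as compound 4 stands at 6.31 nM in this assay on the shared core, while the butyl chain of compound 1 still gives the lower of the two numbers. Nothing measured here accounts for the size of this step, so the result records the change without explaining it.

With only one change at this position in view, the compounds shown cannot separate the effect of the thiophene ring from that of its methyl group, or from the swap of chain for ring as a whole. They also leave open how a plain thiophen-2-yl, a phenyl ring, a propyl chain or a pentyl chain would read in this same place on the core of compound 1.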